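Adding halogens to a benzyl-indole cytotoxic series

This account rests on a few compounds, and the source may have more. Where it says the series, first, only, none or still open, it means among the compounds named here.

Compound 1 `OCc1cn(Cc2ccccc2)c2ccccc12` is the parent of this small set. In a functional assay on NCI-H460 cells (Homo sapiens) for cytotoxicity, read by sulforhodamine B assay, with a stated time of 3 days (on this read-out higher numbers stand for weaker inhibition and lower numbers for stronger inhibition), compound 1 gives 112 nM. Compound 2 `OCc1cn(Cc2cccc(F)c2)c2ccccc12` differs from compound 1 by fluoro in place of hydrogen on an aromatic carbon, and in this assay compound 2 gives 40 nM; the step is a 2.8-fold lower number from compound 1 to compound 2 (0.45 log units; beyond the scatter). Compound 3 `OCc1cn(Cc2ccc(Cl)cc2)c2ccccc12` differs from compound 1 by chloro in place of hydrogen on an aromatic carbon, and in this assay compound 3 gives 16 nM, a step of a 7.0-fold lower number from compound 1 to compound 3 (0.85 log units; beyond the scatter). Compound 4 `OCc1cn(Cc2cccc(F)c2)c2ccc(Cl)cc12` is not yet measured; it differs from compound 2 by chloro in place of hydrogen on an aromatic carbon. This is the same kind of change as from compound 1 to compound 3, but not the same: there the chloro entered a six-membered aromatic ring of carbon only, para to a large group, whereas here it enters a ring that is part of a fused or bridged system of two rings, meta to a fused ring and para to a fused ring. Because the earlier step was a 7.0-fold lower number from compound 1 to compound 3 (0.85 log units; beyond the scatter), a lower number for compound 4 seems plausible, but the different place argues for a smaller step. Compound 4 is expected to give 18 nM in this assay, with a likely range from 6 nM to 50 nM. The expected step is a 2.2-fold lower number from compound 2 to compound 4 (0.35 log units; beyond the scatter).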

Compound 4, half-maximal inhibitory concentration: 70 nM
Estimate against measurement, compound 4: 3.9-fold (0.59 log units) below; measured number outside the range, above it.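

In this assay, chloro in place of hydrogen did not carry over from one core to the other, and the gap between the two steps is larger than the scatter: the same change on two cores in this assay, a 7.0-fold lower number (0.85 log units; beyond the scatter) from compound 1 to compound 3 and a 1.8-fold higher number (0.24 log units; within the scatter) from compound 2 to compound 4, 12-fold (1.09 log units) apart, beyond the scatter of two such steps. The new step, a 1.8-fold higher number from compound 2 to compound 4 (0.24 log units; within the scatter), is too small to read as a change, so on this core the chloro brings no gain that can be seen. What this does not show is the reason: the chloro sits on a different ring in each step, here on a ring that is part of a fused system of two rings, and compound 4 also carries the fluoro, so the effect of place cannot be separated from the effect of core.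

Still open, going by these compounds, is what chloro would do on the ring that holds it in compound 3 with the fluoro also present, and what it would do on the fused system without the fluoro. Also open, on these data alone, is whether another group at this place, such as an amine or a carboxylic acid, would behave as chloro does.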